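The source may report more compounds than this note shows. Statements on the series, on what has been measured and on what is new or still open speak of the compounds shown alone.

Measured so far:
Compound 1, `COc1ccc2c(c1)OC(c1cc(OC)c(OC)c(OC)c1)C(C(=O)Nc1ccccc1)=C2`, 17500 nM
Compound 2, `CCCC(=O)C1=Cc2ccc(OC)cc2OC1c1cc(OC)c(OC)c(OC)c1`, 11700 nM

Both compounds share a core and differ only in the group on the carbonyl carbon. In a functional assay for inhibition of nuclear factor NF-kappa-B complex (Homo sapiens) (on this read-out higher numbers stand for weaker inhibition and lower numbers for stronger inhibition), compound 1 gives 17500 nM, while compound 2 gives 11700 nM. The step of a 1.5-fold lower number from compound 1 to compound 2 (0.17 log units; within the scatter) is within the scatter, so the two numbers should be read as equal; compound 2 has the lower number of the two, but nothing more can be made of that.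

Compound 3, `COc1ccc2c(c1)OC(c1cc(OC)c(OC)c(OC)c1)C(C(=O)O)=C2`, is the next change on the same carbonyl carbon: hydroxy in place of propyl on a carbonyl carbon. Within the data shown here, the only measured step that touches this position is a 1.5-fold lower number from compound 1 to compound 2 (0.17 log units; within the scatter), where swapping one group on that carbon for another left the number essentially unchanged. Among the measured compounds shown here, nothing in the two measurements shows that this position is sensitive, and there is no measured compound carrying a hydroxy here. The expectation for compound 3 is therefore a step of a 1.3-fold higher number from compound 2 to compound 3 (0.11 log units; within the scatter), with no movement beyond the scatter predicted. Compound 3 is estimated at 15000 nM, within a range from 5000 nM to 45000 nM.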

Compound 3, half-maximal inhibitory concentration: > 50000 nM
Compound 3: only a limit was reported; the forecaster's own chance of this, stated with the estimate: 15%; at least 3.3-fold (0.52 log units) between middle value and limit.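

With propyl and anilino on the carbonyl carbon the numbers stayed within the scatter of each other, so the position could have seemed to accept any group, but hydroxy breaks that picture in this assay, giving an at least 4.2-fold higher number from compound 2 to compound 3 (0.63 log units; beyond the scatter) and an at least 2.8-fold higher number from compound 1 to compound 3 (0.45 log units; beyond the scatter). Compound 3 gives > 50000 nM, which is a limit of the assay and not a number, so both steps state only the smallest size the change can have: the limit of > 50000 nM in this assay, at which 1 of the 3 values shown sits. The position is therefore sensitive to at least this one change: going from propylcarbonyl to carboxy weakens inhibition beyond the scatter, whereas going from anilino to propyl on the same carbon did not move the number beyond it.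

These three compounds cannot say what it is about the hydroxy that matters, or how much weaker compound 3 really is. A methoxy or an amino group on the same carbonyl carbon would show whether the loss belongs to the hydroxy itself or to any group of similar size there, and a longer chain in place of propyl would show how much more this carbon accepts.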